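Replacing the 4-methoxyphenyl group of compound 3

The compounds below may be only part of what the source reports. "The series", "measured", "known", "first", "only" and "open" are said of these compounds alone.

Compound 1 `Cc1cccc(NC(=O)C2(C(=O)Nc3ccc(Nc4ncc5cc(C(=O)N(C)C)n(C6CCCC6)c5n4)cc3)CC2)c1` gives 45.7%
Compound 2 `CN(C)C(=O)c1cc2cnc(Nc3ccc(NC(=O)C4(C(=O)Nc5ccc(Cl)cc5)CC4)cc3)nc2n1C1CCCC1` gives 22.8%
Compound 3 `COc1ccc(NC(=O)C2(C(=O)Nc3ccc(Nc4ncc5cc(C(=O)N(C)C)n(C6CCCC6)c5n4)cc3)CC2)cc1` gives 76.4%

All three were read in a functional assay on T47D cells (Homo sapiens) for inhibition, read by CCK-8 assay, with a stated time of 72 h, tested at 1 uM (a higher number here means more inhibition of growth at the concentration tested, a lower number less inhibition of growth), and there compound 3 stands highest at 76.4% and clear of both others. Compound 4 `CN(C)C(=O)c1cc2cnc(Nc3ccc(NC(=O)C4(C(=O)Nc5ccccc5F)CC4)cc3)nc2n1C1CCCC1` has not yet been measured. It carries 2-fluorophenyl in place of 4-methoxyphenyl on an amide-type nitrogen. In counted terms the change reads 2-fluorophenyl in place of 4-methoxyphenyl on an amide-type nitrogen and leaves the rest of the molecule untouched.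

Within the data shown here, two measured steps bear on this change, since each one arrives at the 4-methoxyphenyl group from another group on that same amide-type nitrogen. They are a number 30.7 percentage points higher from compound 1 to compound 3 (beyond the scatter) and a number 53.6 percentage points higher from compound 2 to compound 3 (beyond the scatter) and both are large and beyond the scatter. Read in reverse, they suggest that giving up the 4-methoxyphenyl group lowers the number, and neither other group matched it. Among the measured compounds shown here, only three compounds stand behind this reading, however, and none of them carries 2-fluorophenyl, so the size remains uncertain. A clear fall is expected, of similar size to those two steps. The expected change is a number 38.4 percentage points lower from compound 3 to compound 4 (beyond the scatter) in this estimate. The estimate for compound 4 is 38% and the expected range runs from 15% up to 68% on this scale.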

Compound 4, percent growth inhibition at one concentration: 85.2%
The estimate for compound 4 lay 47.2 percentage points below the measured number; measured number above the stated range.
By their numbers in this assay, from the lowest: compound 2; then compound 1; then compounds 3 and 4 (each within the scatter of the next).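

In this assay, the 4-methoxyphenyl group no longer stands alone at the top of this small series: putting 2-fluorophenyl on the same amide-type nitrogen gives a number 8.8 percentage points higher from compound 3 to compound 4 (within the scatter), so these two quite different groups cannot be told apart here. The other two groups remain clearly separated from the new one, with a number 62.4 percentage points higher from compound 2 to compound 4 (beyond the scatter) and a number 39.5 percentage points higher from compound 1 to compound 4 (beyond the scatter), which shows that a substituted phenyl ring on this nitrogen can give either a high or a low number, so the ring alone does not settle the outcome. Nothing available here explains why the four groups fall where they do.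

The compounds shown carry only substituted phenyl rings on this nitrogen, so they leave open how a plain phenyl, a pyridyl ring or a cyclohexyl group would compare. They also leave open whether the result for 2-fluorophenyl depends on where the fluorine sits, which 3-fluorophenyl and 4-fluorophenyl would test, and how compound 3 and compound 4 would compare at other concentrations.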